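The source may report more compounds than this note shows. Statements on the series, on what has been measured and on what is new or still open speak of the compounds shown alone.

Measured in a functional assay on LOX IMVI cells (Homo sapiens) for cytotoxicity, read by MTT assay, with a stated time of 24 h; on this read-out lower numbers stand for stronger inhibition and higher numbers for weaker inhibition:
compound 1 `COc1ccc(S(=O)(=O)NCCCNc2nccc(-c3[nH]c(-c4ccccc4)nc3-c3ccc(F)c(OC)c3)n2)cc1`: 6130 nM
compound 2 `COc1cc(-c2nc(-c3ccccc3)[nH]c2-c2ccnc(NCCCNS(=O)(=O)c3ccc(F)cc3)n2)ccc1Cl`: 4530 nM
compound 3 `O=S(=O)(NCCCNc1nccc(-c2[nH]c(-c3ccccc3)nc2-c2ccc(F)c(O)c2)n1)c1ccc(F)cc1`: 19200 nM

Compound 3 has the highest number of the three. Compound 4 `COc1ccc(S(=O)(=O)NCCCNc2nccc(-c3[nH]c(-c4ccccc4)nc3-c3ccc(F)c(O)c3)n2)cc1` differs from it by methoxy in place of fluoro on an aromatic carbon, with methoxy in place of fluoro on an aromatic carbon, para to a large group. For the measured compounds named here, no measured step isolates this change. Going by the values given here, the only step available, a 4.2-fold higher number from compound 2 to compound 3 (0.63 log units; beyond the scatter), is modest and concerns another part of the molecule, which compound 4 keeps as in compound 3. Compound 1 carries the same methoxy and gives 6130 nM, but it also differs elsewhere. No shift beyond the scatter is therefore expected, and the estimated step is a 1.1-fold lower number from compound 3 to compound 4 (0.05 log units; within the scatter). For compound 4 the estimate is 17000 nM, with an expected range of 8000 nM to 35000 nM.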

Compound 4, half-maximal inhibitory concentration: 13900 nM
Compound 4: middle estimate off by 1.2-fold (0.09 log units), on the high side; low and high end bracket the measured number.
By their numbers in this assay, from the lowest: compounds 2 and 1 (each within the scatter of the next); then compounds 4 and 3 (each within the scatter of the next).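

In this assay, 4-methoxyphenyl in place of 4-fluorophenyl on the sulfonyl gives a 1.4-fold lower number from compound 3 to compound 4 (0.14 log units; within the scatter), so this position takes either group without a shift beyond the scatter while the hydroxyl on the other ring is present. The earlier step changed two substituents on that other ring at once, whereas hydrogen in place of methyl on its oxygen alone gives a 2.3-fold higher number from compound 1 to compound 4 (0.36 log units; beyond the scatter) and is modest. Nothing available explains either step. From the compounds shown here alone, whether an amine or a carboxylic acid in place of the methoxy would also stay within the scatter remains open.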